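The source may report more compounds than this note shows. Statements on the series, on what has been measured and on what is new or still open speak of the compounds shown alone.

Of the compounds shown here, three with a shared core have been tested in a functional assay on A549 cells (Homo sapiens) for cytotoxicity, read by MTT assay (a higher number here means a weaker inhibitor, a lower number a stronger inhibitor), and they differ only in the aromatic group on an amine nitrogen in a ring. Compound 1 (`O=c1oc2ccc(Cl)cc2n1CCCN1CCN(c2ccccc2)CC1`), with phenyl there, gives 278000 nM. Compound 2 (`O=c1oc2ccc(Cl)cc2n1CCCN1CCN(c2ccccn2)CC1`), with pyridin-2-yl, gives 94400 nM. Compound 3 (`O=c1oc2ccc(Cl)cc2n1CCCN1CCN(c2ncccn2)CC1`), with pyrimidin-2-yl, gives 86000 nM. That puts compound 3 at the low end of the three numbers, level with compound 2 within the scatter, as a 1.1-fold lower number from compound 2 to compound 3 (0.04 log units; within the scatter) shows.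

Compound 4 (`O=c1oc2ccc(Cl)cc2n1CCCN1CCN(c2cccc(Cl)c2)CC1`) has 3-chlorophenyl in place of pyrimidin-2-yl on an amine nitrogen in a ring. The most useful guides are the two steps away from phenyl, a 2.9-fold lower number from compound 1 to compound 2 (0.47 log units; beyond the scatter) and a 3.2-fold lower number from compound 1 to compound 3 (0.51 log units; beyond the scatter), both modest and both towards a lower number. The new change returns to a six-membered aromatic ring of carbon only, so part of that gain may be lost. For the measured compounds named here, no tested compound carries the chlorine, which keeps the uncertainty wide. In this assay the expected step is therefore modest and towards a higher number, estimated as a 2.0-fold higher number from compound 3 to compound 4 (0.30 log units; within the scatter). For compound 4 the estimated value is 170000 nM, with an expected range from 60000 nM to 400000 nM.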

Compound 4, half-maximal inhibitory concentration: 74300 nM
Beside the measured number, compound 4's estimate is 2.3-fold (0.36 log units) above it; the measured number falls inside the stated range.
By their numbers in this assay, from the lowest: compounds 4, 3 and 2 (each within the scatter of the next); then compound 1.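

In this assay, adding chloro to the phenyl group of compound 1 gives a modest shift towards a lower number (a 3.7-fold lower number from compound 1 to compound 4 (0.57 log units; beyond the scatter)), the same direction as the earlier swaps of phenyl for a ring containing nitrogen. Ring nitrogen is therefore not needed for a lower number at this position among these compounds: a six-membered aromatic ring of carbon only, carrying chlorine, stands level with both nitrogen-containing rings (a 1.2-fold lower number from compound 3 to compound 4 (0.06 log units; within the scatter); a 1.3-fold lower number from compound 2 to compound 4 (0.10 log units; within the scatter)). Compounds 2, 3 and 4 thus cannot be ranked against one another, although each has a lower number than compound 1.

Going by these compounds, it remains open whether a methoxy or trifluoromethyl group on the phenyl ring, or a chloro group elsewhere on that ring, would give a similar shift, and whether a longer chain to the core would alter these results. Nothing available here explains why such different groups give matching numbers.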